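Replacing the Ring Amide Hydrogen with Phenyl

A few compounds are considered here, and "the series" means these few. Any claim that something is new, unique, unknown or untested is made for them only; others in the source may bear on it.

Three compounds share one core and differ only in the group on the amide-type nitrogen in the ring. Compound 1 `COc1ccc(N2C(=O)COc3ccc(-c4cnc(Cl)c(NS(=O)(=O)c5ccc(F)cc5)c4)cc32)cc1` carries 4-methoxyphenyl there, and in a functional assay on HeLa cells (Homo sapiens) for antiproliferative activity, read by MTT assay, with a stated time of 72 h (a higher number here means a weaker inhibitor, a lower number a stronger inhibitor), compound 1 gives 8320 nM. Compound 2 `CC(C)N1C(=O)COc2ccc(-c3cnc(Cl)c(NS(=O)(=O)c4ccc(F)cc4)c3)cc21` carries isopropyl, and in this assay compound 2 gives 5380 nM. Compound 3 `O=C1COc2ccc(-c3cnc(Cl)c(NS(=O)(=O)c4ccc(F)cc4)c3)cc2N1` carries hydrogen; in this assay compound 3 gives 15600 nM, the highest number of the three, with compound 1 its nearest neighbour and compound 2 its furthest. The unmeasured compound 4 `O=C1COc2ccc(-c3cnc(Cl)c(NS(=O)(=O)c4ccc(F)cc4)c3)cc2N1c1ccccc1` differs from compound 3 in one place: phenyl in place of hydrogen on an amide-type nitrogen in a ring. Among the compounds with values here, two measured steps bear on this change, both putting hydrogen in place of a larger group on the same nitrogen: a 1.9-fold higher number from compound 1 to compound 3 (0.27 log units; within the scatter) and a 2.9-fold higher number from compound 2 to compound 3 (0.46 log units; beyond the scatter). The change to compound 4 runs the other way. A lower number is therefore expected for compound 4, of a size between those two steps, namely a 2.2-fold lower number from compound 3 to compound 4 (0.35 log units; beyond the scatter). Compound 4 is estimated at 7000 nM in this assay, within a range from 3500 nM to 14000 nM.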

Compound 4, half-maximal inhibitory concentration: 10300 nM
The estimate for compound 4 lay 1.5-fold (0.17 log units) below the measured number, and the stated range covers the measured number.
By their numbers in this assay, from the lowest: compounds 2, 1, 4 and 3 (each within the scatter of the next, the first and the last beyond it).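

Phenyl on the amide-type nitrogen in a ring is not set apart from hydrogen in this assay, as the step to it shows (a 1.5-fold lower number from compound 3 to compound 4 (0.18 log units; within the scatter)), whereas isopropyl was. Phenyl is not set apart from isopropyl either (a 1.9-fold higher number from compound 2 to compound 4 (0.28 log units; within the scatter)), and the methoxy group of the 4-methoxyphenyl substituent makes no readable difference (a 1.2-fold higher number from compound 1 to compound 4 (0.09 log units; within the scatter)), so compound 2 and compound 3 remain the only pair of the four separated beyond the scatter. Nothing measured here explains these results.

On these data alone, it remains open whether a longer chain on this nitrogen would go beyond isopropyl, or would give a step as large as the one isopropyl gives. As far as these compounds go, it is equally open whether an amine or a carboxylic acid on the phenyl ring would set such a compound apart from compound 4 in this assay.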